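Chloro to methyl in a cytotoxicity series

This account rests on a few compounds, and the source may have more. Where it says the series, first, only, none or still open, it means among the compounds named here.

Compound 1 `Nc1ncnc2c1ncn2C[C@@H]1C[C@H](O)c2ccccc21`: > 200000 nM
Compound 2 `OC[C@H]1C[C@@H](Cn2cnc3c(-c4ccc(Cl)cc4)ncnc32)c2ccccc21`: 8440 nM
Compound 3 `COc1ccccc1-c1ncnc2c1ncn2C[C@@H]1C[C@H](O)c2ccccc21`: > 200000 nM

Within the data shown here, in an ADME assay on L1210/0 cells (Mus musculus) for cytotoxicity, with a stated time of 48 h (on this read-out higher numbers stand for weaker inhibition and lower numbers for stronger inhibition), compound 2 gives 8440 nM, and this is the only true number among the three compounds. Compound 1 gives > 200000 nM, which is a limit of the assay and not a number. Compound 3 gives > 200000 nM, which is likewise a limit. The picture is therefore thin, as one line of the record shows: the limit of > 200000 nM in this assay, at which 2 of the 3 values shown sit.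

Compound 4 `Cc1ccc(-c2ncnc3c2ncn3C[C@@H]2C[C@H](CO)c3ccccc32)cc1` differs from compound 2 in a single place: methyl in place of chloro on an aromatic carbon. The 4-chlorophenyl group of compound 2 thus becomes 4-methylphenyl in compound 4.

Among the measured compounds shown here, the only measured step is a step that the two limits leave unreadable from compound 1 to compound 3, and it offers no size to carry over. For the measured compounds named here, it also leaves the chloro group untouched, so no measured step bears directly on this change. Compound 2 at 8440 nM is the sole anchor, so a value near it is expected for compound 4, with no direction that the data could support. The expected outcome is a 1.2-fold higher number from compound 2 to compound 4 (0.07 log units; within the scatter), an estimate and no more. For compound 4 the estimated value in this assay is 10000 nM, with an expected range from 3500 nM to 40000 nM.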

Compound 4, half-maximal inhibitory concentration: 15400 nM
The estimate for compound 4 lay 1.5-fold (0.19 log units) below the measured number; low and high end bracket the measured number.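

In this assay, among these compounds, the exchange of 4-chlorophenyl for 4-methylphenyl gives the first step in this set that can be read as a size: a 1.8-fold higher number from compound 2 to compound 4 (0.26 log units; within the scatter). At this place, on an aromatic carbon para to a large group, the read-out therefore does not separate methyl from chloro. Until now a single number stood alone, whereas compound 2 and compound 4 now form a pair that differs in one place, and both give true numbers rather than limits of the assay.

On these data alone, what a group of another kind would do at this same place stays open, for instance an amine, a carboxylic acid or a longer chain such as butyl, and a single pair says nothing about such groups. Beyond this pair, the compounds shown offer little that can be compared in numbers: the limit of > 200000 nM in this assay, at which 2 of the 4 values shown sit.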